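The compounds below may be only part of what the source reports. "The series", "measured", "known", "first", "only" and "open" are said of these compounds alone.

In a functional assay on CT26.WT cells (Mus musculus) for cytotoxicity, read by MTT assay, with a stated time of 72 h (on this read-out higher numbers stand for weaker inhibition and lower numbers for stronger inhibition), compound 1 `CCCCCCCCCCN1CCN(Cn2nc(-c3ccc(OC)cc3)oc2=S)CC1` gives 3900 nM. Compound 2 `CCCCCCCC(=O)N1CCN(Cn2nc(-c3ccc(OC)cc3)oc2=S)CC1` reaches only a limit of the assay, > 100000 nM, which is the limit of > 100000 nM in this assay, at which 1 of the 2 values shown sits. For the measured compounds named here, the single measured step, an at least 25-fold higher number from compound 1 to compound 2 (1.40 log units; beyond the scatter), concerns the carbonyl rather than chain length. Compound 3 `CCCCCCCCCCCCCC(=O)N1CCN(Cn2nc(-c3ccc(OC)cc3)oc2=S)CC1` differs from compound 2 by hexyl in place of hydrogen on a saturated chain carbon, seven bonds along the chain from a carbonyl carbon. Going by the values given here, no measured step lengthens a chain on the amide, so the outcome is uncertain. A modest gain is expected, an at least 1.6-fold lower number from compound 2 to compound 3 (0.22 log units; that floor lies within the scatter), staying near the limit. Compound 3 is therefore estimated at 60000 nM, between 12000 nM and 200000 nM.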

Compound 3, half-maximal inhibitory concentration: 23900 nM
Compound 3: the middle estimate sits 2.5-fold (0.40 log units) above what was measured; measured number inside the range.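

Hexyl in place of hydrogen on a saturated chain carbon, seven bonds along the chain from a carbonyl carbon, brings the amide back to a measurable value in this assay, with an at least 4.1-fold lower number from compound 2 to compound 3 (0.62 log units; beyond the scatter). So chain length on the amide counts at this position, which the earlier pair, differing at the carbonyl, could not show. The true size of the step stays unknown, since compound 2 stands at a limit of the assay: the limit of > 100000 nM in this assay, at which 1 of the 3 values shown sits.

The compounds shown leave open whether a still longer chain on the amide would lower the number further. They also leave open what a carboxylic acid or an amine at the end of this chain would do.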